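Swapping the 3,4,5-trimethoxyphenyl group of compound 1

This account rests on a few compounds, and the source may have more. Where it says the series, first, only, none or still open, it means among the compounds named here.

- compound 1 `COc1cc(CN(C(=O)CSc2nc3ccccc3s2)c2cc(OC)c(OC)c(OC)c2)cc(OC)c1OC` gives 45700 nM
- compound 2 `COc1ccc(CN(C(=O)CSc2nc3cc(Br)ccc3s2)c2cc(OC)c(OC)c(OC)c2)cc1O` gives 372 nM

In a functional assay on MGC-803 cells (Homo sapiens) for antiproliferative activity, read by MTT assay, with a stated time of 48 h (on this read-out higher numbers stand for weaker inhibition and lower numbers for stronger inhibition), compound 1 has the higher of the two numbers, and compound 2 lies lower by well beyond the usual scatter. Compound 3 `COc1ccc(CN(C(=O)CSc2nc3ccccc3s2)c2cc(OC)c(OC)c(OC)c2)cc1N` carries 3-amino-4-methoxyphenyl in place of 3,4,5-trimethoxyphenyl on a saturated chain carbon bound to an amide-type nitrogen. Among the measured compounds shown here, no measured pair differs in one place, so the size of the step remains uncertain. Since compound 2 reaches 372 nM in this assay a large downward step is expected. The estimated change is a 30-fold lower number from compound 1 to compound 3 (1.48 log units; beyond the scatter) toward stronger inhibition. For compound 3 the expected value is 1500 nM (estimated range 200 nM to 15000 nM).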

Compound 3, half-maximal inhibitory concentration: 84 nM
Compound 3: the middle estimate sits 18-fold (1.25 log units) above what was measured; measured number outside the range, below it.
By their numbers in this assay, from the lowest: compound 3; then compound 2; then compound 1.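

In this assay the swap of 3,4,5-trimethoxyphenyl for 3-amino-4-methoxyphenyl on a saturated chain carbon bound to an amide-type nitrogen gives a 540-fold lower number from compound 1 to compound 3 (2.74 log units; beyond the scatter) with the rest of the structure unchanged. Among the compounds shown here, this is the first reading of this position alone, and it shows that this single change is enough for a large move toward stronger inhibition. Nothing available explains the size of this step.

The compounds shown do not separate the gain of the amino group from the loss of the other methoxy groups. As far as these compounds go, how a dimethylamino or acetamido group would compare with the amino group also remains open.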